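Swapping a Furan Arm for a Methoxyphenyl Arm

A few compounds are considered here, and "the series" means these few. Any claim that something is new, unique, unknown or untested is made for them only; others in the source may bear on it.

Three compounds built on one shared core were tested in a functional assay on ileum for antagonist activity at muscarinic acetylcholine receptor M3 (Cavia porcellus); a lower number here means a stronger inhibitor, a higher number a weaker inhibitor. Compound 1 `C#CCN1CCN(CC(=O)C(O)(c2ccccc2)C2CCCCC2)CC1` gives 260 nM in this assay. Compound 2 `O=C(CN1CCC(N2CCCC2)CC1)C(O)(c1ccccc1)C1CCCCC1` gives 349 nM. Compound 3 `O=C(CN1CCN(Cc2ccco2)CC1)C(O)(c1ccccc1)C1CCC1` gives 750 nM, the highest of the three numbers, and since its gaps to both compound 2 and compound 1 lie beyond the usual scatter, compound 3 is the weakest inhibitor of the set.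

Compound 4 `COc1ccccc1N1CCN(CC(=O)C(O)(c2ccccc2)C2CCC2)CC1` has not yet been measured. It differs from compound 3 in a single place: 2-methoxyphenyl in place of (furan-2-yl)methyl on an amine nitrogen in a ring. The rest of the molecule is unchanged.

Among the measured compounds shown here, none of the measured compounds differ from one another in just one place, so no measured step isolates this kind of exchange, and the expectation for compound 4 rests on the structural change alone. A step of modest size is expected, leaning toward a somewhat higher number than compound 3, but quite possibly staying within the scatter. In this assay compound 4 is estimated at 1000 nM, with a likely range from 350 nM to 3000 nM. This estimate corresponds to an expected step of a 1.3-fold higher number from compound 3 to compound 4 (0.12 log units; within the scatter).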

Compound 4, antagonist equilibrium constant: > 10000 nM
Compound 4: no number, only a limit (the forecaster's own chance of this, stated with the estimate: 5%); middle value at least 10-fold (1.00 log units) from the limit.
By their numbers in this assay, from the lowest: compounds 1 and 2 (each within the scatter of the next); then compound 3. At a limit, above all of these: compound 4.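

In this assay compound 4 gives > 10000 nM, which is a limit of the assay and not a number: the limit of > 10000 nM in this assay, at which 1 of the 4 values shown sits. Replacing (furan-2-yl)methyl with 2-methoxyphenyl on this amine nitrogen in a ring gives an at least 13-fold higher number from compound 3 to compound 4 (1.12 log units; beyond the scatter), a large step and the first one here that isolates a single place, showing that activity in this series can depend strongly on the group at this nitrogen. The two groups have the same counts of hydrogen-bond donors and acceptors and neither carries a net charge, so those counts alone do not predict the loss seen with this exchange.

This single exchange changes the aromatic ring and the way it is attached together, so it cannot show which difference matters, or how far activity falls beyond the limit. A plain benzyl group or a 2-methoxybenzyl group on the same nitrogen would help separate these features, and the same exchange on the core of compound 1 would test whether the large step carries over to a different shared framework.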